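Enaminone series: trifluoromethyl in place of chloro

The source may report more compounds than this note shows. Statements on the series, on what has been measured and on what is new or still open speak of the compounds shown alone.

Measured so far in a functional assay on PC-3 cells (Homo sapiens) for antiproliferative activity, read by MTT assay, with a stated time of 48 h; on this read-out higher numbers stand for weaker inhibition and lower numbers for stronger inhibition:
compound 1 `O=C(/C=C\Nc1ccc(C(F)(F)F)cc1)c1cn(-c2ccccc2)nc1-c1ccccc1`: > 50000 nM (a limit)
compound 2 `O=C(/C=C\Nc1ccc(F)cc1)c1cn(-c2ccccc2)nc1-c1ccc(F)cc1`: 7900 nM
compound 3 `O=C(/C=C\Nc1ccc(Cl)cc1)c1cn(-c2ccccc2)nc1-c1ccc(F)cc1`: 3800 nM

Compound 3 gives the lowest number of the two numbers measured; compound 2 sits a 2.1-fold lower number from compound 2 to compound 3 (0.32 log units; beyond the scatter) away. Compound 1 reaches only the limit of > 50000 nM in this assay, at which 1 of the 3 values shown sits, and gives no number. Compound 4 `O=C(/C=C\Nc1ccc(C(F)(F)F)cc1)c1cn(-c2ccccc2)nc1-c1ccc(F)cc1` is unmeasured; it differs from compound 3 by trifluoromethyl in place of chloro on an aromatic carbon. Among the compounds with values here, compound 1 carries the same trifluoromethyl group on its anilino ring, and the gap between compound 1 and compound 4 is on the other ring, for which no step is measured. Within the data shown here, the only measured step, a 2.1-fold lower number from compound 2 to compound 3 (0.32 log units; beyond the scatter), is modest, and compound 1 reached a limit. The number for compound 4 is therefore expected to rise from compound 3 by a 3.2-fold higher number from compound 3 to compound 4 (0.50 log units; beyond the scatter). Compound 4 is estimated at 12000 nM in this assay, between 3500 nM and 50000 nM.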

Compound 4, half-maximal inhibitory concentration: > 50000 nM
Compound 4: only a limit was reported; the forecaster's own chance of this, stated with the estimate: 30%; middle value at least 4.1-fold (0.61 log units) from the limit.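

At this position, para to a large group, the chloro-to-trifluoromethyl change costs far more than the halogen change did, with an at least 13-fold higher number from compound 3 to compound 4 (1.11 log units; beyond the scatter). Against fluoro, the same change gives an at least 6.3-fold higher number from compound 2 to compound 4 (0.80 log units; beyond the scatter), so in this assay both halogens give numbers while trifluoromethyl does not. Compound 1 and compound 4, both with trifluoromethyl, now share a limit of the assay and not a number: the limit of > 50000 nM in this assay, at which 2 of the 4 values shown sit.

The step from compound 1 to compound 4 cannot be read, which leaves fluoro in place of hydrogen on the other ring unresolved. Going by these compounds, whether bromo, methoxy or a nitrile at this position stays near compound 3 also remains open.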